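Removing the Chloro Group from Compound 3

A few compounds are considered here, and "the series" means these few. Any claim that something is new, unique, unknown or untested is made for them only; others in the source may bear on it.

Compound 3 `Cc1cc(C)n2nc(SCc3cc(=O)c4cc(Cl)ccc4o3)nc2n1` was tested in a functional assay on LM7 cells (Homo sapiens) for cytotoxicity, read by MTT assay, with a stated time of 72 h (a higher number here means a weaker inhibitor, a lower number a stronger inhibitor), where it gives > 25000 nM; this is a limit of the assay rather than a measured number. Compound 1 `Cc1ccc2oc(CSc3nnc(N)s3)cc(=O)c2c1` also gives only a limit, > 25000 nM. Compound 2 `Cc1nnc(SCc2cc(=O)c3cc(Cl)ccc3o2)s1` likewise gives a limit, > 25000 nM. Compound 3 thus stands with the others at the limit of > 25000 nM in this assay, at which 3 of the 3 values shown sit, and none of the three separates from the rest. Compound 4 `Cc1cc(C)n2nc(SCc3cc(=O)c4ccccc4o3)nc2n1` differs from compound 3 by hydrogen in place of chloro on an aromatic carbon. Among the measured compounds shown here, no measured pair shows what such a change does here, so no step beyond the scatter is expected in either direction. Compound 4 is therefore expected to give about 35000 nM, between 12000 nM and 100000 nM. The step that the limit leaves unreadable from compound 3 to compound 4 is estimated to be essentially none, and the assay is expected most likely to report only a limit again.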

Compound 4, half-maximal inhibitory concentration: > 25000 nM
Compound 4 gave a limit, no number; the forecaster's own chance of this, stated with the estimate: 85%; the middle value lies beyond the limit too.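

Among the compounds shown here, compound 3 and compound 4 both stop at a limit of the assay, so no step between them can be read: the limit of > 25000 nM in this assay, at which 4 of the 4 values shown sit. The compounds shown leave open whether the chloro group has any effect on cytotoxicity, and which change would give a measurable value.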